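Chain extension in the methylpiperazine amides

A few compounds are considered here, and "the series" means these few. Any claim that something is new, unique, unknown or untested is made for them only; others in the source may bear on it.

Compound 3 `COc1ccc(-c2oc3c(OC)c(OC)cc(OCCCCC(=O)N4CCN(C)CC4)c3c(=O)c2O)cc1` gives > 40000 nM in a functional assay on A549 cells (Homo sapiens) for antiproliferative activity, read by sulforhodamine B assay, with a stated time of 48 h (on this read-out lower numbers stand for stronger inhibition and higher numbers for weaker inhibition), and this is a limit of the assay. Compound 1 `COc1ccc(-c2oc3c(OC)c(OC)cc(OCCCC(=O)N4CCN(C)CC4)c3c(=O)c2O)cc1` gives > 40000 nM, which is also a limit. Within the data shown here, compound 2 `CCCCN(C)C(=O)CCCCOc1cc(OC)c(OC)c2oc(-c3ccc(OC)cc3)c(O)c(=O)c12` gives 16700 nM, the only number so far in this assay. The series therefore shows (the limit of > 40000 nM in this assay, at which 2 of the 3 values shown sit), and compound 3 has no exact position.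

Compound 4 `COc1ccc(-c2oc3c(OC)c(OC)cc(OCCCCCC(=O)N4CCN(C)CC4)c3c(=O)c2O)cc1` differs from compound 3 as follows: ((4-methylpiperazin-1-yl)carbonyl)methyl in place of (4-methylpiperazin-1-yl)carbonyl on a saturated chain carbon, four bonds along the chain from an oxygen on an aromatic ring. The same kind of replacement, three bonds along the chain from an oxygen on an aromatic ring, gave a step that the two limits leave unreadable from compound 1 to compound 3. Among the measured compounds shown here, the only readable steps concern the amide group: an at least 2.3-fold lower number from compound 1 to compound 2 (0.37 log units; beyond the scatter), and an at least 2.3-fold higher number from compound 2 to compound 3 (0.37 log units; beyond the scatter). Neither step changes the 4-methylpiperazin-1-yl amide chain alone, so neither gives a size for this extension. Given the limit of > 40000 nM for compound 3, no step beyond the scatter is expected in this assay. The expected step is a number no higher from compound 3 to compound 4 (the limit leaves the size open). Compound 4 is estimated at 40000 nM, with an expected range of 20000 nM to 80000 nM.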

Compound 4, half-maximal inhibitory concentration: 14800 nM
Estimate against measurement, compound 4: 2.7-fold (0.43 log units) above; the measured number lies below the stated range.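

In this assay, lengthening the chain at this position gives the first readable gain for the 4-methylpiperazin-1-yl amides: an at least 2.7-fold lower number from compound 3 to compound 4 (0.43 log units; beyond the scatter), and over the wider chain change, an at least 2.7-fold lower number from compound 1 to compound 4 (0.43 log units; beyond the scatter). The 4-methylpiperazin-1-yl amide therefore does not rule out a measurable value, as the comparison with the butyl(methyl)amino amide shows: a 1.1-fold lower number from compound 2 to compound 4 (0.05 log units; within the scatter). The two shorter-chain 4-methylpiperazin-1-yl amides, compound 1 and compound 3, remain at the assay limit: the limit of > 40000 nM in this assay, at which 2 of the 4 values shown sit.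

As far as these compounds go, the true size of the gain stays open, since both steps start from a limit. Also open, from the compounds shown here alone, is whether a longer chain carries the trend further, and whether a morpholine amide or a free carboxylic acid at the chain end would behave like compound 4.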